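Bromo in Place of Chloro: from Compound 2 to Compound 3

The source may report more compounds than this note shows. Statements on the series, on what has been measured and on what is new or still open speak of the compounds shown alone.

Measured so far:
compound 1 `CC(C)(C)N(NC(=O)c1cccc(Br)c1)C(=O)c1ccccc1Cl`: 191 nM
compound 2 `CC(C)(C)N(NC(=O)c1ccc(Cl)cc1)C(=O)c1ccccc1Cl`: 115 nM

Among the compounds with values here, in an assay on cells for agonist activity at ecdysone receptor (Bombyx mori), read by a luciferase reporter, with a stated time of 24 h (on this read-out lower numbers stand for an effect already at smaller amounts and higher numbers for an effect only at larger amounts of compound), compound 2 shows the smaller of the two numbers, yet the one measured step, a 1.7-fold lower number from compound 1 to compound 2 (0.22 log units; within the scatter), does not set the two compounds apart. Compound 3 `CC(C)(C)N(NC(=O)c1ccc(Br)cc1)C(=O)c1ccccc1Cl` is reached through (bromo in place of chloro on an aromatic carbon). Within the data shown here, no measured step exchanges one halogen for another at the same place; the step from compound 1 to compound 2 alters halogen and position together and bears on this change only loosely. The estimate for compound 3 is therefore a step of no more than the scatter, a 1.0-fold lower number from compound 2 to compound 3 (0.02 log units; within the scatter), giving 110 nM with a range from 50 nM to 250 nM.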

Compound 3, half-maximal effective concentration: 33.9 nM
Beside the measured number, compound 3's estimate is 3.2-fold (0.51 log units) above it; measured number below the stated range.
By their numbers in this assay, from the lowest: compound 3; then compounds 2 and 1 (each within the scatter of the next).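

In this assay the change to bromo brings a 3.4-fold lower number from compound 2 to compound 3 (0.53 log units; beyond the scatter) and is the only single exchange of one halogen for another shown here. With bromo kept, the change of place brings a 5.6-fold lower number from compound 1 to compound 3 (0.75 log units; beyond the scatter) and shows that the halogen's place also matters, which the earlier step could not separate from the change of halogen. Nothing available explains either step. Going by these compounds, what iodo or methoxy would do at this place remains open, as does whether the change from chloro to bromo would give a similar step on the 3-substituted ring.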